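Aryl ether changes in the ABHD12 series

A few compounds are considered here, and "the series" means these few. Any claim that something is new, unique, unknown or untested is made for them only; others in the source may bear on it.

Measured compounds:
compound 1 `FC(F)(F)Oc1ccc(Oc2ccnc(N3CCC(NC(=S)Nc4cccnc4)CC3)c2Cl)cc1`: 25 nM
compound 2 `FC(F)(F)Oc1cccc(Oc2ccnc(N3CCC(NC(=S)Nc4cccnc4)CC3)c2Cl)c1`: 89 nM

Two compounds have numbers in an assay on membranes from brain for binding affinity to Lysophosphatidylserine lipase ABHD12 (Mus musculus), read by fluorescence, with a stated time of 20 min (on this read-out higher numbers stand for weaker inhibition and lower numbers for stronger inhibition), where compound 1 gives 25 nM and compound 2 gives 89 nM. Among the measured compounds shown here, compound 2 holds the higher of the two numbers; its nearest neighbour is compound 1, and the only measured step in the set is a 3.6-fold higher number from compound 1 to compound 2 (0.55 log units; beyond the scatter).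

Compound 3 `FC(F)(F)Oc1ccc(Oc2ccnc(N3CCC(NC(=S)Nc4cccnc4)CC3)c2Cl)cc1Cl` awaits measurement. The change from compound 2 is 3-chloro-4-(trifluoromethoxy)phenyl in place of 3-(trifluoromethoxy)phenyl on an oxygen on an aromatic ring. This restores the trifluoromethoxy group to the arrangement seen in compound 1 and adds a chlorine to that ring. For the measured compounds named here, the step from compound 1 to compound 2 is the only one that bears on it, and it works in reverse here; the added chlorine has no measured counterpart in the set, so its contribution is unknown. The expectation is a return toward the number of compound 1, a lower number in this assay, estimated as a 3.0-fold lower number from compound 2 to compound 3 (0.47 log units; beyond the scatter). Compound 3 is therefore expected at about 30 nM, with a range from 10 nM to 90 nM.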

Compound 3, half-maximal inhibitory concentration: 33 nM
The estimate for compound 3 lay 1.1-fold (0.04 log units) below the measured number, and the stated range covers the measured number.
By their numbers in this assay, from the lowest: compounds 1 and 3 (each within the scatter of the next); then compound 2.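

In this assay, chloro in place of hydrogen on an aromatic carbon of the 4-(trifluoromethoxy)phenyl group gives a 1.3-fold higher number from compound 1 to compound 3 (0.12 log units; within the scatter) and so shows that this ring carries the extra chlorine without a change that can be read on this measure. Putting 3-chloro-4-(trifluoromethoxy)phenyl in place of 3-(trifluoromethoxy)phenyl on the oxygen gives a 2.7-fold lower number from compound 2 to compound 3 (0.43 log units; beyond the scatter) as a modest step, which shows that this aryl ether position can return to the lower range with the larger group of the two. Among the three compounds shown, the two with the 4-(trifluoromethoxy) arrangement share that lower range, while compound 2 alone stands apart, and no available evidence accounts for either step. 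

Still open, on these data alone, is whether a smaller group such as 3-chlorophenyl, with no trifluoromethoxy at all, would stay in that lower range. Also open, as far as these compounds go, is whether a methoxy group, a nitrile or an amine in place of the added chloro would be carried as readily on this ring, and whether the same steps would hold on a different core.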